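The compounds below may be only part of what the source reports. "The series", "measured", "known", "first", "only" and "open" are said of these compounds alone.

The study measures inhibition in an assay on HEK293 cells for inhibition of Fatty-acid amide hydrolase 1 (Homo sapiens), read by fluorescence; a higher number here means a weaker inhibitor, a lower number a stronger inhibitor. Compound 1, with structure `NC(=O)c1cccc(-c2ccc3oc(NC4CCCCC4)nc3c2)c1`, gives only a limit of the assay in this assay, namely > 1000 nM. Compound 2, with structure `N#Cc1cc(-c2ccc3oc(NC4CCCCC4)nc3c2)ccc1O`, gives 54 nM in this assay. Compound 3, with structure `Cn1ccc2cc(-c3ccc4oc(Nc5ccccc5)nc4c3)ccc21`, gives 48 nM in this assay, the lowest of the two numbers shown; the gap to compound 2 is within the usual scatter, so the two cannot be ranked against each other. The third value shown sits at the limit described by the limit of > 1000 nM in this assay, at which 1 of the 3 values shown sits.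

Compound 4, with structure `C[C@@H]1CN(c2nc3cc(-c4ccc5c(ccn5C)c4)ccc3o2)C[C@H](C)O1`, has not yet been measured in this assay. It differs from compound 3 in one place: 2,6-dimethylmorpholin-4-yl in place of anilino on an aromatic carbon. For the measured compounds named here, no measured pair in this set shares this kind of change, so no measured step can be pointed to for guidance, and the hydrogen-bond donor that leaves with the anilino group is absent in compound 4.

In the absence of such a step, compound 4 is expected to lose some potency, and the step of a 4.2-fold higher number from compound 3 to compound 4 (0.62 log units; beyond the scatter) is estimated as a moderate rise beyond the scatter. Compound 4 is therefore estimated to give 200 nM in this assay, with a range from 50 nM to 1000 nM.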

Compound 4, half-maximal inhibitory concentration: 168 nM
For compound 4 the middle estimate is 1.2-fold (0.08 log units) above the measured one; the measured number falls inside the stated range.
By their numbers in this assay, from the lowest: compounds 3 and 2 (each within the scatter of the next); then compound 4. At a limit, above all of these: compound 1.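

In this assay, replacing anilino with 2,6-dimethylmorpholin-4-yl on this aromatic carbon, next to the ring nitrogen and the ring oxygen, gives a 3.5-fold higher number from compound 3 to compound 4 (0.54 log units; beyond the scatter) and still leaves a measured number, not a limit of the assay. Among the compounds shown, only compound 4 has a group without a hydrogen-bond donor at this place, and its non-aromatic ring with 2 hetero atoms and 2 defined stereocentres shows that this position tolerates more than an amino group carrying a hydrogen. Several features change together in this single step, however, and nothing measured here explains the rise in the number.

The compounds shown leave open whether the modest step follows from the missing donor, the loss of the aromatic ring, the ring oxygen or the two methyl groups, and an unsubstituted morpholine or a piperidine at this place would help to separate these. They also leave open how the other stereoisomers of the 2,6-dimethylmorpholin-4-yl group compare, and whether the same replacement gives a similar step when the hydroxyl- and nitrile-bearing ring of compound 2 stands on the core.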